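The source may hold more compounds than are shown below. What is called first, only, known or untested is meant among the compounds shown, and "the series" means these compounds.

Measured so far, in a functional assay on HL-60 cells (Homo sapiens) for cytotoxicity, read by WST assay, with a stated time of 48 h; on this read-out higher numbers stand for an effect only at larger amounts of compound and lower numbers for an effect already at smaller amounts:

compound 1, `CCCCCCCOc1ccccc1C[C@H]1C(=O)OC[C@@H]1Cc1ccccc1`, gives 75000 nM;
compound 2, `Cc1ccccc1C[C@H]1C(=O)OC[C@@H]1Cc1ccccc1`, gives 57000 nM;
compound 3, `CCCCCCCOc1cccc(C[C@H]2C(=O)OC[C@@H]2Cc2ccccc2)c1`, gives 81000 nM.

The three numbers lie close together, and the gaps among them are within the scatter of the measurement. From compound 1 to compound 2 the change is methyl in place of heptyloxy on an aromatic carbon, and the step it made, a 1.3-fold lower number from compound 1 to compound 2 (0.12 log units; within the scatter), is within the scatter. Compound 4, `Cc1cccc(C[C@H]2C(=O)OC[C@@H]2Cc2ccccc2)c1`, is not yet measured. It arises from compound 3 by methyl in place of heptyloxy on an aromatic carbon. Going by the values given here, this is the same kind of change as the one from compound 1 to compound 2, but the surroundings differ: in compound 1 the group sits ortho to a large group, in compound 3 meta to a large group. Compound 1 and compound 3 have the same atoms joined differently; the difference between the two cores is not broken down here. Because the change from compound 1 to compound 2 gave a 1.3-fold lower number from compound 1 to compound 2 (0.12 log units; within the scatter), a step of similar size is expected from compound 3 to compound 4, namely a 1.2-fold lower number from compound 3 to compound 4 (0.10 log units; within the scatter), in this assay. Compound 4 is therefore estimated at 65000 nM, likely between 35000 nM and 120000 nM.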

Compound 4, half-maximal effective concentration: 53000 nM
The estimate for compound 4 lay 1.2-fold (0.09 log units) above the measured number; low and high end bracket the measured number.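

In this assay methyl in place of heptyloxy gave a 1.5-fold lower number from compound 3 to compound 4 (0.18 log units; within the scatter) on this core, while 3-methylphenyl in place of 2-methylphenyl gave a 1.1-fold lower number from compound 2 to compound 4 (0.03 log units; within the scatter) when only the two methyl compounds are compared. Neither step stands out from the ordinary spread of repeated measurements, so these compounds do not show that a change with a clear effect would carry over from one core to the other, and they give no reason for the small size of the steps. What they do show is a modest kind of transfer, with the swap staying small on both cores: the same change on two cores in this assay, a 1.3-fold lower number (0.12 log units; within the scatter) from compound 1 to compound 2 and a 1.5-fold lower number (0.18 log units; within the scatter) from compound 3 to compound 4, 1.2-fold (0.07 log units) apart, within the scatter of two such steps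

The compounds shown carry only heptyloxy or methyl on this aromatic ring, so it remains open whether an amine, a carboxylic acid or a chain shorter than heptyloxy, such as ethoxy, would move the number by more than the scatter. From the compounds shown here alone, it also remains open whether such a group would behave alike on both cores.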